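The source may report more compounds than this note shows. Statements on the series, on what has been measured and on what is new or still open speak of the compounds shown alone.

In a functional assay on HT-29 cells (Homo sapiens) for cytotoxicity, read by sulforhodamine B assay (a lower number here means a stronger inhibitor of growth, a higher number a weaker inhibitor of growth), compound 1 (`CC1=CC[C@@H]([C@@](C)(O)CCCC(C)(C)NC(=S)N/N=C\c2ccc(O)cc2)CC1`) gives 31500 nM and compound 2 (`CC1=CC[C@@H]([C@@](C)(O)CCCC(C)(C)NC(=S)N/N=C\c2ccccc2[N+](=O)[O-])CC1`) gives 16800 nM, so the two stand within the scatter of each other. Compound 3 (`CC1=CC[C@@H]([C@@](C)(O)CCCC(C)(C)NC(=S)N/N=C\c2ccc([N+](=O)[O-])cc2)CC1`) differs from compound 2 by 4-nitrophenyl in place of 2-nitrophenyl on a carbon with a double bond to nitrogen, with 4-nitrophenyl in place of 2-nitrophenyl on a carbon with a double bond to nitrogen. Going by the values given here, the only measured step that bears on this change is a 1.9-fold lower number from compound 1 to compound 2 (0.27 log units; within the scatter), which alters the group at the same place. No change beyond the scatter is therefore expected in this assay, in either direction. The expected step is a 1.1-fold higher number from compound 2 to compound 3 (0.05 log units; within the scatter). For compound 3 the estimated value is 19000 nM, with an expected range of 9000 nM to 40000 nM.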

Compound 3, concentration for total growth inhibition: 62800 nM
Compound 3: middle estimate off by 3.3-fold (0.52 log units), on the low side, and the stated range ends below it.
By their numbers in this assay, from the lowest: compounds 2, 1 and 3 (each within the scatter of the next, the first and the last beyond it).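

In this assay, 4-nitrophenyl in place of 2-nitrophenyl gives a 3.7-fold higher number from compound 2 to compound 3 (0.57 log units; beyond the scatter), so two groups with the same atoms, on a carbon with a double bond to nitrogen, can be told apart at this place. Nitro in place of hydroxy on an aromatic carbon gives a 2.0-fold higher number from compound 1 to compound 3 (0.30 log units; within the scatter), so that change does not clear the scatter. No measurement is at hand that accounts for the gap between compound 2 and compound 3. As far as these compounds go, whether an amine or a carboxylic acid on the phenyl ring would stand nearer compound 2 or compound 3 remains open.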